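Swapping an aromatic amide cap for a branched alkyl chain

The compounds below may be only part of what the source reports. "The series", "measured", "known", "first", "only" and "open" are said of these compounds alone.

Three compounds share one core and differ only in the group attached to one carbonyl carbon. Compound 1 `Cc1ccccc1C(=O)Nc1ccc2nc(NC(=O)C3CCCCC3)sc2c1` gives 0.085 ug/mL in a functional assay on WI-38 VA13 cells (Homo sapiens) for cytotoxicity (a lower number here means that less compound is needed, a higher number that more compound is needed for the effect), the lowest of the three numbers. Compound 2 `O=C(Nc1ccc2nc(NC(=O)C3CCCCC3)sc2c1)c1ccccc1F` gives 0.14 ug/mL, and the step of a 1.6-fold higher number from compound 1 to compound 2 (0.22 log units; within the scatter) lies within the scatter. Compound 3 `Cc1ccc(C(=O)Nc2ccc3nc(NC(=O)C4CCCCC4)sc3c2)cc1` gives 5.1 ug/mL, and the steps of a 60-fold higher number from compound 1 to compound 3 (1.78 log units; beyond the scatter) and a 36-fold higher number from compound 2 to compound 3 (1.56 log units; beyond the scatter) are both large.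

Compound 4 `CCCC(C)C(=O)Nc1ccc2nc(NC(=O)C3CCCCC3)sc2c1` has not yet been measured. Relative to compound 1, the change is 1-methylbutyl in place of 2-methylphenyl on a carbonyl carbon. The large steps to compound 3 show that the group on this carbonyl carbon matters a great deal, while the step to compound 2 shows that a small swap within a 2-substituted ring costs little. Within the data shown here, no measured step replaces the aromatic ring with a chain, so the direction is uncertain. A loss of some size is expected for compound 4, that is a 12-fold higher number from compound 1 to compound 4 (1.07 log units; beyond the scatter). Compound 4 is therefore estimated at 1 ug/mL, with a range from 0.15 ug/mL to 8 ug/mL.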

Compound 4, half-maximal effective concentration: 0.14 ug/mL
Beside the measured number, compound 4's estimate is 7.1-fold (0.85 log units) above it; the measured number lies below the stated range.
By their numbers in this assay, from the lowest: compounds 1, 2 and 4 (each within the scatter of the next); then compound 3.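

In this assay an aromatic ring on this carbonyl carbon is not needed for a low number: 1-methylbutyl gives a 1.6-fold higher number from compound 1 to compound 4 (0.22 log units; within the scatter) and no change at the digits printed from compound 2 to compound 4 (within the scatter) even though it has no ring and fewer heavy atoms than 2-methylphenyl. The step of a 36-fold lower number from compound 3 to compound 4 (1.56 log units; beyond the scatter) confirms that compound 3 is the one that stands apart, so among these four compounds the presence of a ring does not by itself set the number: compounds 1 and 2 carry a ring and group with the ringless compound 4, while compound 3 carries a ring and does not.

As far as these compounds go, whether an unbranched pentyl chain, a longer chain, or a chain bearing an amine or a carboxylic acid would also group with compound 4 remains open. No supporting measurement is available to explain why the chain and the 2-methylphenyl ring give such similar numbers.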